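Swapping fluoro for hydroxy on compound 2

This account rests on a few compounds, and the source may have more. Where it says the series, first, only, none or still open, it means among the compounds named here.

In a functional assay on PANC-1 cells (Homo sapiens) for inhibition, read by MTT assay, with a stated time of 24 h (on this read-out lower numbers stand for stronger inhibition and higher numbers for weaker inhibition), two compounds have been measured so far
- Compound 1 `CC1(C)[C@H]2CC[C@]1(C)N(Cc1cn(-c3ccccc3Br)nn1)C(=O)C2` gives 280 nM
- Compound 2 `CC1(C)[C@H]2CC[C@]1(C)N(Cc1cn(-c3ccc(F)cc3)nn1)C(=O)C2` gives 110 nM

For the measured compounds named here, compound 2 holds the lower of these two numbers, and compound 1 is its only neighbour. The next compound, compound 3 `CC1(C)[C@H]2CC[C@]1(C)N(Cc1cn(-c3ccc(O)cc3)nn1)C(=O)C2`, keeps the shared core and carries hydroxy in place of fluoro on an aromatic carbon. This turns 4-fluorophenyl into 4-hydroxyphenyl.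

Going by the values given here, only one measured step bears on this change (a 2.5-fold lower number from compound 1 to compound 2 (0.41 log units; beyond the scatter)). It is modest, though beyond the scatter. Among the compounds with values here, it also alters the group on the aromatic nitrogen, but no measured compound carries a hydroxy, so the data give no firm direction for the new step. A modest change in this assay is therefore the reasonable expectation, with a slight lean towards a higher number held only loosely. The expected size is a 1.4-fold higher number from compound 2 to compound 3 (0.13 log units; within the scatter) in this read-out. The estimate for compound 3 is 150 nM (expected range 50 nM to 450 nM).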

Compound 3, half-maximal inhibitory concentration: 100 nM
Compound 3: the middle estimate sits 1.5-fold (0.18 log units) above what was measured; the measured number falls inside the stated range.
By their numbers in this assay, from the lowest: compounds 3 and 2 (each within the scatter of the next); then compound 1.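

In this assay, putting hydroxy in place of fluoro gives a 1.1-fold lower number from compound 2 to compound 3 (0.04 log units; within the scatter), so on this aromatic carbon, para to a large group, the read-out does not separate the two groups, even though the count gives hydroxy a hydrogen-bond donor and a hydrogen-bond acceptor that fluoro lacks. The comparison with the bromine compound gives a 2.8-fold lower number from compound 1 to compound 3 (0.45 log units; beyond the scatter), so among the three compounds, both 4-substituted phenyl groups carry lower numbers than 2-bromophenyl, although that step changes both the group and where it sits on the ring. Nothing measured alongside these numbers offers a reason for this result.

The compounds shown leave open whether this carbon would keep its number with a larger or different group, such as methoxy, an amine or a carboxylic acid. They also leave open whether hydroxy or fluoro would give a similar number at the ring position that holds bromine in compound 1, which would separate the effect of the group from the effect of its place.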